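This account rests on a few compounds, and the source may have more. Where it says the series, first, only, none or still open, it means among the compounds named here.

Three compounds here share one core and differ only at a saturated chain carbon bound to an aromatic nitrogen: compound 1 `CCOC(=O)c1sc(-c2nc3ccccc3n2C)nc1C`, compound 2 `CCOC(=O)c1sc(-c2nc3ccccc3n2CC)nc1C` and compound 3 `CCOC(=O)c1sc(-c2nc3ccccc3n2Cc2ccccc2)nc1C`. In a functional assay on MCF7 cells (Homo sapiens) for cytotoxicity, read by MTT assay, with a stated time of 24 h (a higher number here means a weaker inhibitor, a lower number a stronger inhibitor), compound 1 reaches only the limit > 20000 nM. In this assay compound 2 likewise gives only the limit > 20000 nM. Compound 3 in this assay also gives only the limit > 20000 nM. The steps a step that the two limits leave unreadable from compound 1 to compound 2, a step that the two limits leave unreadable from compound 1 to compound 3 and a step that the two limits leave unreadable from compound 2 to compound 3 therefore cannot be sized, because of the limit of > 20000 nM in this assay, at which 3 of the 3 values shown sit. Compound 4 `Cc1nc(-c2nc3ccccc3n2Cc2ccccc2)sc1C(=O)O` differs from compound 3 by hydrogen in place of ethyl on an oxygen next to a carbonyl group. Going by the values given here, no measured step touches this position, and the known steps give no size to work from. Compound 4 is thus expected to stay at the limit, with an estimated value of 30000 nM (range 8000 nM to 100000 nM), an expected step that the limit leaves unreadable from compound 3 to compound 4 of no readable size.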

Compound 4, half-maximal inhibitory concentration: > 20000 nM
Compound 4: only a limit was reported; the forecaster's own chance of this, stated with the estimate: 80%; the middle value does not contradict the limit.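

No size can be read for the change from ethoxycarbonyl to carboxy between compound 3 and compound 4, because both results are limits, not numbers: the limit of > 20000 nM in this assay, at which 4 of the 4 values shown sit. The compounds shown leave open how strongly any of compounds 1 to 4 acts in this assay.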